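Aryl variation on the shared core: microsomal half-life notes

The compounds below may be only part of what the source reports. "The series", "measured", "known", "first", "only" and "open" are said of these compounds alone.

compound 1 `Nc1nc(NCCNc2ncc(-c3ncc[nH]3)c(-c3ccccc3Cl)n2)ccc1[N+](=O)[O-]` — > 0.5 h
compound 2 `Nc1nc(NCCNc2ncc(-c3ncc[nH]3)c(-c3ccc(F)cc3F)n2)ccc1[N+](=O)[O-]` — > 0.5 h
compound 3 `Nc1nc(NCCNc2ncc(-c3ncc[nH]3)c(-c3cc(F)ccc3Cl)n2)ccc1[N+](=O)[O-]` — > 0.5 h

In an ADME assay on microsomes from liver (Rattus norvegicus) for metabolic stability (on this read-out lower numbers stand for a shorter-lived compound and higher numbers for a longer-lived compound), compound 3 gives > 0.5 h, which is a limit of the assay and not a number. Compound 1 likewise gives > 0.5 h, a limit. Compound 2 gives > 0.5 h, again a limit. All three values sit at the limit of > 0.5 h in this assay, at which 3 of the 3 values shown sit, so a step that the two limits leave unreadable from compound 1 to compound 3 and a step that the two limits leave unreadable from compound 2 to compound 3 carry no readable size, and the same holds for a step that the two limits leave unreadable from compound 1 to compound 2. The next compound, compound 4 `Nc1nc(NCCNc2ncc(-c3ncc[nH]3)c(-c3ccc(Br)cc3Cl)n2)ccc1[N+](=O)[O-]`, differs from compound 3 by 4-bromo-2-chlorophenyl in place of 2-chloro-5-fluorophenyl on an aromatic carbon. The two steps bearing on this change are both unreadable, so no step beyond the scatter can be expected in this assay in either direction. Compound 4 is expected to give about 1 h (0.5 h to 2 h), most likely reported once more as a limit. The implied step that the limit leaves unreadable from compound 3 to compound 4 is an estimate only.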

Compound 4, half-life: > 0.5 h
Compound 4: a limit, no number; the forecaster's own chance of this, stated with the estimate: 80%; the middle value is on the limit's open side.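

Compound 4 gives > 0.5 h, a limit and not a number, so its steps from compound 1, compound 2 and compound 3 cannot be read. The compounds shown leave open whether any of these aryl changes on the shared core alters the half-life at all: the limit of > 0.5 h in this assay, at which 4 of the 4 values shown sit.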